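The source may hold more compounds than are shown below. What is called first, only, known or untested is meant among the compounds shown, and "the series" means these compounds.

Compound 1 `Nc1nn2c(O)cc(-c3ccc(F)cc3)nc2c1[N+](=O)[O-]`: > 100 ug/mL (a limit)
Compound 2 `Nc1nn2c(O)cc(CCl)nc2c1[N+](=O)[O-]`: > 50 ug/mL (a limit)

In an ADME assay (Homo sapiens) for cytotoxicity (on this read-out higher numbers stand for lower toxicity in this test and lower numbers for higher toxicity in this test), compound 2 gives > 50 ug/mL, which is a limit of the test and not a number. Compound 1 gives > 100 ug/mL, also a limit. Neither compound therefore has an exact value. Compound 3 `Nc1nn2c(O)cc(CNCCO)nc2c1[N+](=O)[O-]` has (2-hydroxyethyl)amino in place of chloro on a saturated chain carbon bound to an aromatic carbon. Going by the values given here, the only measured step that bears on this change is a step that the two limits leave unreadable from compound 1 to compound 2, which puts chloromethyl in place of 4-fluorophenyl on an aromatic carbon. It gives no size to carry over, so the expectation in this assay rests on the two limits alone. The expected step is a step that the limit leaves unreadable from compound 2 to compound 3, with no shift in either direction beyond the usual scatter. For compound 3 the estimated value is 80 ug/mL, with an expected range of 30 ug/mL to 200 ug/mL.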

Compound 3, half-maximal cytotoxic concentration: > 50 ug/mL
Compound 3 was reported as a limit; the forecaster's own chance of this, stated with the estimate: 65%; the middle value lies beyond the limit too.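

In this assay compound 3 gives > 50 ug/mL, a limit of the test and not a number. Going by these compounds alone, compound 1 and compound 2 also carry limits, so no step among the three can be read. The compounds shown leave open whether any of these group changes shifts toxicity in this test at all.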